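A Hydroxy Group Added to a Second Core

The source may report more compounds than this note shows. Statements on the series, on what has been measured and on what is new or still open speak of the compounds shown alone.

Of the compounds shown here, three have been measured in a functional assay on NSCLC cells (Homo sapiens) for inhibition, with a stated time of 48 h; a lower number here means a stronger inhibitor of growth, a higher number a weaker inhibitor of growth. Compound 1 `COc1cc2c(/C=C3/C(=O)N(C)c4ccccc43)c(Cl)n(C)c2cc1C` gives 33100 nM. Compound 2 `COc1cc2c(/C=C3/C(=O)N(C)c4ccc(O)cc43)c(Cl)n(C)c2cc1C` carries a hydroxy group where compound 1 carries a hydrogen, and in this assay compound 2 gives 6030 nM. That change, (hydroxy in place of hydrogen on an aromatic carbon), made a step of a 5.5-fold lower number from compound 1 to compound 2 (0.74 log units; beyond the scatter). Compound 3 `COc1cc2c(/C=C3/C(=O)N(C)c4ccccc43)c[nH]c2cc1C` is built on a different core; the difference between the two cores is not broken down here. In this assay compound 3 gives 66100 nM, and this number and that of compound 1 lie within the scatter of each other, so no order between them is claimed.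

Compound 4 `COc1cc2c(/C=C3/C(=O)N(C)c4ccc(O)cc43)c[nH]c2cc1C` is compound 3 with the same change applied: hydroxy in place of hydrogen on an aromatic carbon. The place of the change is described in the same words as before. Going by the values given here, only one earlier instance of this change is known, so the expectation rests on it alone. The step is expected to be about as large as the earlier one, a 5.1-fold lower number from compound 3 to compound 4 (0.71 log units; beyond the scatter), because that earlier instance gave a 5.5-fold lower number from compound 1 to compound 2 (0.74 log units; beyond the scatter). Compound 4 is therefore estimated at 13000 nM, with a likely range from 5000 nM to 35000 nM.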

Compound 4, concentration for total growth inhibition: 21900 nM
Compound 4: the middle estimate sits 1.7-fold (0.23 log units) below what was measured; measured number inside the range.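

On the second core the hydroxy group again gives a lower number in this assay, with a 3.0-fold lower number from compound 3 to compound 4 (0.48 log units; beyond the scatter), so the change carried over from one core to the other in its direction. The two steps also count as the same size, as the gap between them stays within what two such steps can show by scatter alone: the same change on two cores in this assay, a 5.5-fold lower number (0.74 log units; beyond the scatter) from compound 1 to compound 2 and a 3.0-fold lower number (0.48 log units; beyond the scatter) from compound 3 to compound 4, 1.8-fold (0.26 log units) apart, within the scatter of two such steps. This rests on just two pairs in one assay, so it shows that the step held on these two cores, but not that it would hold on any further core, and it does not explain why the hydroxy group has this effect.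

Going by these compounds, whether a different group in the same place, such as an amine or a fluorine atom, would lower the number as well remains open. Also open, on these data alone, is whether the hydroxy group would give a similar step elsewhere on that ring.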